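From a Cyclohexyl Ring to a Phenyl Ring at Sulfur

The source may report more compounds than this note shows. Statements on the series, on what has been measured and on what is new or still open speak of the compounds shown alone.

Compound 1 `Cc1cc(N2CC[C@@H](C)[C@@H](N(C)c3ncnc4[nH]ccc34)C2)n2nc(SCC3CCCCC3)nc2n1` was tested in a functional assay on BGC-823 cells (Homo sapiens) for inhibition, read by MTT assay, with a stated time of 72 h (a lower number here means a stronger inhibitor, a higher number a weaker inhibitor), where compound 1 gives 16300 nM, the smallest of the three numbers available. Compound 3 `Cc1cc(N2CC[C@@H](C)[C@@H](N(C)c3ncnc4[nH]ccc34)C2)n2nc(SCCc3ccccc3)nc2n1` gives 28000 nM, and compound 2 `Cc1cc(N2CC[C@@H](C)[C@@H](N(C)c3ncnc4[nH]ccc34)C2)n2nc(SCc3ccccc3Br)nc2n1` gives 81100 nM. Compound 4 `Cc1cc(N2CC[C@@H](C)[C@@H](N(C)c3ncnc4[nH]ccc34)C2)n2nc(SCc3ccccc3)nc2n1` has not been measured; it differs from compound 1 by phenyl in place of cyclohexyl on a saturated chain carbon bound to a sulfur. For the measured compounds named here, two measured steps bear on this change. Benzyl in place of cyclohexyl gave a 1.7-fold higher number from compound 1 to compound 3 (0.23 log units; within the scatter), 2-bromophenyl in place of cyclohexyl gave a 5.0-fold higher number from compound 1 to compound 2 (0.70 log units; beyond the scatter), and a 2.9-fold lower number from compound 2 to compound 3 (0.46 log units; beyond the scatter) places the benzyl variant between them. Because compound 1 gives 16300 nM and the benzyl variant gave only a 1.7-fold higher number from compound 1 to compound 3 (0.23 log units; within the scatter), a modest rise is expected for compound 4, estimated as a 1.5-fold higher number from compound 1 to compound 4 (0.19 log units; within the scatter). The value expected for compound 4 in this assay is 25000 nM, with a range from 10000 nM to 60000 nM.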

Compound 4, half-maximal inhibitory concentration: 14400 nM
Compound 4: the middle estimate sits 1.7-fold (0.24 log units) above what was measured, within the range that was stated.
By their numbers in this assay, from the lowest: compounds 4, 1 and 3 (each within the scatter of the next); then compound 2.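

In this assay, phenyl in place of cyclohexyl gives a 1.1-fold lower number from compound 1 to compound 4 (0.05 log units; within the scatter), so swapping the non-aromatic ring for the aromatic one on the carbon bound to sulfur has no readable effect. Phenyl in place of benzyl gives a 1.9-fold lower number from compound 3 to compound 4 (0.29 log units; within the scatter), which also lies within the scatter. For the compounds shown here, only hydrogen in place of bromo on an aromatic carbon gives a step beyond the scatter, a 5.6-fold lower number from compound 2 to compound 4 (0.75 log units; beyond the scatter), which isolates the bromo as the one change here that separates compound 2 from compound 4.

As far as these compounds go, whether an amine or a carboxylic acid on the phenyl ring would shift the number remains open. Nothing measured here explains why these compounds give the numbers they do.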